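Swapping the drawn geometry of a thiosemicarbazone

The source may hold more compounds than are shown below. What is called first, only, known or untested is meant among the compounds shown, and "the series" means these compounds.

Measured compounds:
`C/C(=N\NC(=S)Nc1ccc(I)cc1)c1ccccn1` compound 1: 59 nM
`C/C(=N\NC(=S)Nc1ccccc1)c1ccccn1` compound 2: 1.4 nM

Compound 1 was tested in a functional assay on U-87MG ATCC cells (Homo sapiens) for cytotoxicity, read by MTT assay, with a stated time of 48 h (on this read-out lower numbers stand for stronger inhibition and higher numbers for weaker inhibition), and gives 59 nM, the higher of the two numbers, so it is the weaker of the two measured compounds. Among the measured compounds shown here, its only neighbour is compound 2, reached by a 42-fold lower number from compound 1 to compound 2 (1.62 log units; beyond the scatter).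

Compound 3 `C/C(=N/NC(=S)Nc1ccc(I)cc1)c1ccccn1` is the subject here. It differs from compound 1 as follows: the two compounds have the same atoms and bonds and differ only in configuration as drawn: 1 of 1 stereo elements differ; a double bond is drawn E in compound 1 and Z in compound 3. For the measured compounds named here, the one measured step concerns a substituent on an aromatic carbon, not a change in drawn configuration, so it does not bear on this change. Going by the values given here, with no comparable step available, no step beyond the scatter is expected in this assay from compound 1 to compound 3, no change at the digits printed from compound 1 to compound 3 (within the scatter), while a wide range is kept. Compound 3 is therefore expected to give about 59 nM, within 12 nM to 300 nM.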

Compound 3, half-maximal inhibitory concentration: 59 nM
Compound 3: the middle estimate sits on the measured number at the digits printed; measured number inside the range.
By their numbers in this assay, from the lowest: compound 2; then compounds 1 and 3 (each within the scatter of the next).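

In this assay, turning the double bond from E to Z gives no change at the digits printed from compound 1 to compound 3 (within the scatter), so this read-out does not separate the two drawn forms of the iodo compound. The earlier step, a 42-fold lower number from compound 1 to compound 2 (1.62 log units; beyond the scatter), came from a change of substituent and said nothing about the double bond. This new pair isolates that feature, and the comparison is direct because nothing else changes: the fact that compounds 1 and 3 differ only in the configuration as drawn

The compounds shown leave open whether the double-bond geometry would matter as little with hydrogen in place of iodo, as in compound 2. They also leave open whether the same would hold with a methoxy group or a carboxylic acid on that aromatic carbon.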